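Compound 3 to compound 4 at the assay limit

A few compounds are considered here, and "the series" means these few. Any claim that something is new, unique, unknown or untested is made for them only; others in the source may bear on it.

Measured compounds in a functional assay on MCF7 cells (Homo sapiens) for inhibition, read by MTT assay, with a stated time of 72 h (a lower number here means a stronger inhibitor, a higher number a weaker inhibitor), follow.
Compound 1 `C=C[C@]1(C)C[C@@H](OC(=O)CNC(=O)Nc2cccc(Br)c2)[C@]2(C)[C@H](C)CC[C@]3(CCC(=O)[C@H]32)[C@@H](C)[C@@H]1O` gives > 10000 nM as a limit.
Compound 2 `C=C[C@]1(C)C[C@@H](OC(=O)CNC(=O)NC(=O)c2ccc(Br)cc2)[C@]2(C)[C@H](C)CC[C@]3(CCC(=O)[C@H]32)[C@@H](C)[C@@H]1O` gives > 10000 nM as a limit.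
Compound 3 `C=C[C@]1(C)C[C@@H](OC(=O)CNC(=O)NC(=O)c2cccc(F)c2)[C@]2(C)[C@H](C)CC[C@]3(CCC(=O)[C@H]32)[C@@H](C)[C@@H]1O` gives > 10000 nM as a limit.

Compound 3 stands at the limit of > 10000 nM in this assay, at which 3 of the 3 values shown sit, and so offers no number to start from. Compound 4 `C=C[C@]1(C)C[C@@H](OC(=O)CNC(=O)Nc2ccc(Cl)cc2)[C@]2(C)[C@H](C)CC[C@]3(CCC(=O)[C@H]32)[C@@H](C)[C@@H]1O` differs from it by 4-chlorophenyl in place of (3-fluorophenyl)carbonyl on an amide-type nitrogen and carries 4-chlorophenyl in place of (3-fluorophenyl)carbonyl on an amide-type nitrogen. The closest measured change is a step that the two limits leave unreadable from compound 1 to compound 3 and it sets (3-fluorophenyl)carbonyl in place of 3-bromophenyl on such a nitrogen. Also bearing on it is a step that the two limits leave unreadable from compound 2 to compound 3 and neither has a size that can be read. No step beyond the scatter is therefore expected in this assay and no direction can be given. The expected step is a step that the limit leaves unreadable from compound 3 to compound 4 and it rests on the limit alone. Compound 4 is expected near 20000 nM within a range of 7000 nM to 50000 nM as its estimate. The assay will most likely report only a limit for it.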

Compound 4, half-maximal inhibitory concentration: > 10000 nM
Compound 4: only a limit was reported; the forecaster's own chance of this, stated with the estimate: 85%; the middle value does not contradict the limit.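

No step can be read from compound 4 to compound 1, compound 2 or compound 3 in this assay, because all four compounds share one limit: the limit of > 10000 nM in this assay, at which 4 of the 4 values shown sit.

The compounds shown leave open which group on the amide-type nitrogen, if any, would give a readable value in this assay.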